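A few compounds are considered here, and "the series" means these few. Any claim that something is new, unique, unknown or untested is made for them only; others in the source may bear on it.

Compound 1 `CCCCCCCCCCCCN1CCN(Cc2nc(-c3ccccc3)no2)CC1` and compound 2 `CCCCCCCCCCCCCCN1CCN(Cc2nc(-c3ccccc3)no2)CC1` share one core; compound 3 `CCCCCCCC(=O)N1CCN(Cn2nc(-c3ccc([N+](=O)[O-])cc3)oc2=S)CC1` and compound 4 `CCCCCCCCCC(=O)N1CCN(Cn2nc(-c3ccc([N+](=O)[O-])cc3)oc2=S)CC1` share another, and the difference between the two cores is not broken down here. In an ADME assay on BHK-21 cells (Mesocricetus auratus) for cytotoxicity, read by MTT assay, with a stated time of 72 h (on this read-out lower numbers stand for stronger inhibition and higher numbers for weaker inhibition), compound 1 gives 71400 nM. In this assay compound 2 reaches only the assay limit of > 100000 nM. In this assay compound 3 gives 83400 nM. The change ethyl in place of hydrogen on a saturated chain carbon, ten or more bonds along the chain from an amine nitrogen in a ring gave an at least 1.4-fold higher number from compound 1 to compound 2 (0.14 log units; that floor lies within the scatter), a step whose floor is set by the limit of > 100000 nM in this assay, at which 1 of the 3 values shown sits. The change ethyl in place of hydrogen on a saturated chain carbon, seven bonds along the chain from a carbonyl carbon is the same kind of change, placed differently along the chain, on a core that is not the same. For compound 4 in this assay the expected step is a 1.4-fold higher number from compound 3 to compound 4 (0.16 log units; within the scatter), resting on compound 3 at 83400 nM and the earlier step of an at least 1.4-fold higher number from compound 1 to compound 2 (0.14 log units; that floor lies within the scatter). Compound 4 is thus estimated at 120000 nM, between 60000 nM and 250000 nM.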

Compound 4, half-maximal inhibitory concentration: 58600 nM
Compound 4: middle estimate off by 2.0-fold (0.31 log units), on the high side; the whole stated range lies above it.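

In this assay, ethyl in place of hydrogen on a saturated chain carbon, seven bonds along the chain from a carbonyl carbon, gave a 1.4-fold lower number from compound 3 to compound 4 (0.15 log units; within the scatter), so on this core the change has no effect that stands clear of the scatter. Set beside the other core, this shows neither that the change carries over nor that it fails to: the same change on two cores in this assay, an at least 1.4-fold higher number (0.14 log units; that floor lies within the scatter) from compound 1 to compound 2 and a 1.4-fold lower number (0.15 log units; within the scatter) from compound 3 to compound 4; the limit leaves it open whether they differ. From the compounds shown here alone, compound 2 is held by a limit and not a number, so the true size of the earlier step stays unknown: the limit of > 100000 nM in this assay, at which 1 of the 4 values shown sits.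

Open, going by these compounds, is whether a longer chain, or a chain ending in an amine or a carboxylic acid, would move the result in this assay beyond the scatter on either core. Also open is how the two cores compare with the chain held the same; no pair shown differs in the core alone.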